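Two limits on the shared core and a cyanosulfanyl variant

The source may hold more compounds than are shown below. What is called first, only, known or untested is meant among the compounds shown, and "the series" means these compounds.

compound 1 `[SeH]c1nc2ccccc2s1` — > 50000 nM
compound 2 `C[Se]c1nc2ccccc2s1` — > 100000 nM

In a functional assay on PC-3 cells (Homo sapiens) for cytotoxicity, read by MTT assay, with a stated time of 72 h (on this read-out lower numbers stand for stronger inhibition of growth and higher numbers for weaker inhibition of growth), compound 1 `[SeH]c1nc2ccccc2s1` gives > 50000 nM, which is a limit of the assay and not a number. In this assay compound 2 `C[Se]c1nc2ccccc2s1` gives > 100000 nM, again a limit of the assay rather than a number. The step that the two limits leave unreadable from compound 1 to compound 2 is therefore unreadable; the only evidence shown is the limit of > 50000 nM in this assay, at which 1 of the 2 values shown sits, and (the limit of > 100000 nM in this assay, at which 1 of the 2 values shown sits). Compound 2 thus stands at a limit only, with no number to place it.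

Compound 3 `N#CSc1nc2ccccc2s1` differs from compound 2 by a group of 3 heavy atoms (1 carbon, 1 nitrogen, 1 sulfur; no ring) in place of a group of 2 heavy atoms (1 carbon, 1 selenium; no ring), on an aromatic carbon, in words a group of 3 heavy atoms (1 carbon, 1 nitrogen, 1 sulfur; no ring) in place of a group of 2 heavy atoms (1 carbon, 1 selenium; no ring), on an aromatic carbon. Going by the values given here, no measured step bears on this change, the single measured step being unreadable. The expectation for compound 3 rests only on the two limits, so no step beyond the scatter is expected in this assay; the step of an at least 1.2-fold lower number from compound 2 to compound 3 (0.09 log units; that floor lies within the scatter) is an estimate from a limit. Compound 3 is estimated at 80000 nM, range 20000 nM to 300000 nM, and most likely reported again as a limit.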

Compound 3, concentration for 50% growth inhibition: 42000 nM
Estimate against measurement, compound 3: 1.9-fold (0.28 log units) above; low and high end bracket the measured number.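

In this assay, going by these compounds alone, compound 3 gives the first number on the shared core, so this place, an aromatic carbon next to the ring nitrogen and next to the ring sulfur, can now be read as one where a change moves growth inhibition into measurable range. Cyanosulfanyl here gives an at least 2.3-fold lower number from compound 2 to compound 3 (0.37 log units; beyond the scatter), while the comparison with the free selenium group gives only an at least 1.1-fold lower number from compound 1 to compound 3 (0.07 log units; that floor lies within the scatter). Compound 2 remains a limit of the assay, so the first of these steps is a floor and not a size: the limit of > 100000 nM in this assay, at which 1 of the 3 values shown sits.

The compounds shown leave open whether the sulfur or the nitrile of cyanosulfanyl carries the change; a methylsulfanyl group or a bare nitrile at this place would separate the two. From the compounds shown here alone, how an amine or a carboxylic acid at this place would read also stays open.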